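A few compounds are considered here, and "the series" means these few. Any claim that something is new, unique, unknown or untested is made for them only; others in the source may bear on it.

Of the compounds shown here, three built on one shared core have been measured in a functional assay on KB cells (Homo sapiens) for cytotoxicity, read by MTT assay, with a stated time of 72 h; a higher number here means a weaker inhibitor, a lower number a stronger inhibitor. Compound 1 `O=C(NC(=S)NNc1ncnc2ccccc12)c1ccccc1F` gives 2510 nM. Compound 2 `COc1cc2ncnc(NNC(=S)NC(=O)c3ccccc3OC)c2cc1OC` gives 3850 nM, and compound 3 `COc1cc2ncnc(NNC(=S)NC(=O)c3ccc(F)cc3)c2cc1OC` gives 4530 nM; all three numbers lie within the usual scatter of one another, so compound 1 stands with the other two rather than apart from them. Compound 4 `O=C(NC(=S)NNc1ncnc2ccccc12)c1ccc(Cl)cc1` differs from compound 1 by 4-chlorophenyl in place of 2-fluorophenyl on a carbonyl carbon. Among the compounds with values here, the only measured step of a similar kind, a swap of the aryl group on the carbonyl carbon, is a 1.2-fold higher number from compound 2 to compound 3 (0.07 log units; within the scatter), which stayed within the scatter. On that basis the expected step in this assay is none beyond the scatter, a 1.1-fold higher number from compound 1 to compound 4 (0.05 log units; within the scatter). In this assay compound 4 is therefore expected to give about 2800 nM, between 1200 nM and 6500 nM.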

Compound 4, half-maximal inhibitory concentration: 3940 nM
Estimate against measurement, compound 4: 1.4-fold (0.15 log units) below, and the stated range covers the measured number.
By their numbers in this assay, from the lowest: compounds 1, 2, 4 and 3 (each within the scatter of the next).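

Replacing 2-fluorophenyl with 4-chlorophenyl on the carbonyl carbon gives a 1.6-fold higher number from compound 1 to compound 4 (0.20 log units; within the scatter) in this assay, so an aryl swap at this place also stays within the scatter on the core of compound 1, as it did in a 1.2-fold higher number from compound 2 to compound 3 (0.07 log units; within the scatter). The step changes the halogen and its ring position together, so neither can be read alone. Nothing shown here explains the result. On these data alone, whether an aminophenyl, a carboxylic acid or a longer alkyl chain on this carbonyl carbon would move the number beyond the scatter remains open.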